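The compounds below may be only part of what the source reports. "The series", "measured", "known", "first", "only" and "open" are said of these compounds alone.

Working notes on the series. Among the measured compounds shown here, compound 1 `Cc1ccc(NC2=CC(=O)c3nc4n(c3C2=O)[C@H]2OC[C@@H](O)[C@H]2OC4)cc1C` is the only member with a numerical result: in a functional assay on HeLa cells (Homo sapiens) for inhibition, read by sulforhodamine B assay (a higher number here means a weaker inhibitor, a lower number a stronger inhibitor), compound 1 gives 2690 nM. Compound 2 `O=C1C(N2CCCCC2)=CC(=O)c2c1nc1n2[C@H]2OC[C@@H](O)[C@H]2OC1` carries a piperidinyl group on the same core. In this assay compound 2 reaches only the assay's limit, > 16000 nM; this is a limit rather than a number (the limit of > 16000 nM in this assay, at which 1 of the 2 values shown sits). For the measured compounds named here, no step between measured compounds is available, so nothing here counts as established structure–activity.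

Compound 3 `O=C1C=C(NC2CCCC2)C(=O)c2c1nc1n2[C@H]2OC[C@@H](O)[C@H]2OC1` is not yet measured. It differs from compound 1 at one point: cyclopentyl in place of 3,4-dimethylphenyl on an amine nitrogen. Cut one bond further out, the change reads (3,4-dimethylphenyl)amino to cyclopentylamino, a secondary amine retained while the aromatic ring is replaced by a saturated one.

Expectation for compound 3: a loss of potency beyond the scatter, on the order of a 3.0-fold higher number from compound 1 to compound 3 (0.47 log units; beyond the scatter). In this assay compound 3 is estimated at 8000 nM, with a plausible range of 3000 nM to 20000 nM.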

Compound 3, half-maximal inhibitory concentration: > 16000 nM
Compound 3: no number, only a limit (the forecaster's own chance of this, stated with the estimate: 30%); middle value at least 2.0-fold (0.30 log units) away from the limit.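

At the amine nitrogen, the result gives this series its first readable step: in this assay, cyclopentyl in place of 3,4-dimethylphenyl produces an at least 5.9-fold higher number from compound 1 to compound 3 (0.77 log units; beyond the scatter). The activity measured for compound 1 therefore does not survive this replacement of an aromatic ring with a saturated one, and the direction of the change is established even though its full size is not. Compound 3 gives > 16000 nM, which is a limit and not a number, so the step has a lower bound only: the limit of > 16000 nM in this assay, at which 2 of the 3 values shown sit.

The compounds shown do not separate the contribution of the aromatic ring from that of its two methyl groups, which a plain phenyl group on the same nitrogen would address. On these data alone, whether ring size also matters remains open, and a cyclohexyl group would speak to that.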